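This account rests on a few compounds, and the source may have more. Where it says the series, first, only, none or still open, it means among the compounds named here.

Measured so far:
compound 1 `COc1ccc(/C=C/C(=O)c2ccc(OC)c3c2OC(C)(C)C=C3)cc1OCC=C(C)C`: > 10000 nM
compound 2 `C=CC(=O)Oc1cc(/C=C/C(=O)c2ccc(OC)c3c2OC(C)(C)C=C3)ccc1OC`: 160 nM

Among the compounds with values here, in a functional assay on HepG2 cells (Homo sapiens) for cytotoxicity, read by MTT assay (on this read-out higher numbers stand for weaker inhibition and lower numbers for stronger inhibition), compound 2 gives 160 nM, the only true number so far. Compound 1 gives > 10000 nM, which is a limit of the assay and not a number.

Compound 3 `COc1ccc(/C=C/C(=O)Oc2cc(/C=C/C(=O)c3ccc(OC)c4c3OC(C)(C)C=C4)ccc2OC)cc1` is still to be measured. It keeps the shared core and the carbonyl of compound 2, with 2-(4-methoxyphenyl)ethenyl in place of vinyl on a carbonyl carbon.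

Within the data shown here, one measured step bears on this change: an at least 62-fold lower number from compound 1 to compound 2 (1.79 log units; beyond the scatter). That step put vinylcarbonyl in place of 3-methylbut-2-en-1-yl on an oxygen on an aromatic ring, so it concerns the same substituent but not the same replacement. It shows that this substituent can shift the number widely in this assay, and a large part of that gain may not survive the new group. The direction is therefore expected to be toward a higher number, though one step is thin support. The expected size is a 16-fold higher number from compound 2 to compound 3 (1.19 log units; beyond the scatter). A limit reading for compound 3 also remains possible. For compound 3 the estimated value is 2500 nM, with an expected range of 500 nM to 10000 nM.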

Compound 3, half-maximal inhibitory concentration: 430 nM
The estimate for compound 3 lay 5.8-fold (0.76 log units) above the measured number; measured number outside the range, below it.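

In this assay, the vinyl group is not essential for a low number at this position: a 2.7-fold higher number from compound 2 to compound 3 (0.43 log units; beyond the scatter). The change to 2-(4-methoxyphenyl)ethenyl on a carbonyl carbon therefore costs a modest amount, and a large separation from the 3-methylbut-2-en-1-yl ether remains, so that separation is not tied to the vinyl group alone: an at least 23-fold lower number from compound 1 to compound 3 (1.36 log units; beyond the scatter). Compound 1 gives > 10000 nM, which is a limit of the assay and not a number, so the true size of both steps that involve it stays open: the limit of > 10000 nM in this assay, at which 1 of the 3 values shown sits.

Both groups seen on this carbonyl carbon carry a double bond, so the compounds shown do not separate the role of that double bond from the role of the carbonyl itself, and an ethyl group in the same place would bear on this question. Also open, on these data alone, is how far the aromatic end of the new group can vary in this assay, for instance with an amine or a carboxylic acid in place of the methoxy group on the 2-(4-methoxyphenyl)ethenyl group.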